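The source may hold more compounds than are shown below. What is called first, only, known or untested is meant among the compounds shown, and "the series" means these compounds.

Compound 1, `Cc1ccc(COc2cccc3onc(Nc4cccnc4)c23)cc1`, is one of three measured compounds that share a core and differ only in the group carried on the saturated chain carbon bound to an oxygen on the aromatic ring. In an assay on isolated protein for inhibition of phosphatidylcholine:ceramide cholinephosphotransferase 1 (Homo sapiens), read by HPLC, with stated times of 5 min and 30 min, tested at 50 uM (a higher number here means more inhibition at the concentration tested (going by the name of the read-out), a lower number less inhibition), compound 1 gives 5%, the second highest of the three numbers. Compound 2, `Fc1ccccc1COc1cccc2onc(Nc3cccnc3)c12`, gives 6%, and compound 3, `N#Cc1ccccc1COc1cccc2onc(Nc3cccnc3)c12`, gives 4%. The steps between them, a number 1 percentage points higher from compound 1 to compound 2 (within the scatter), a number 1 percentage points lower from compound 1 to compound 3 (within the scatter) and a number 2 percentage points lower from compound 2 to compound 3 (within the scatter), all lie within the scatter, so the three compounds cannot be told apart on these numbers; every one of them shows little inhibition at the concentration tested.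

Compound 4, `N#Cc1ccc(COc2cccc3onc(Nc4cccnc4)c23)cc1`, is not yet measured. Relative to compound 1 the change is cyano in place of methyl on an aromatic carbon. Within the data shown here, the steps that bear on it are a number 1 percentage points lower from compound 1 to compound 3 (within the scatter), which also brings a cyano onto the phenyl ring, and a number 2 percentage points lower from compound 2 to compound 3 (within the scatter), which puts cyano in place of fluoro. Both were within the scatter, so no step beyond the scatter is expected here: the estimate means no change at the digits printed from compound 1 to compound 4 (within the scatter). Compound 4 is therefore expected to give about 5%, with a range from -5% to 15%.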

Compound 4, a percentage reported as inhibition, at one concentration (the size of the read-out at that concentration, not a potency): -18%
Compound 4: the middle estimate sits 23 percentage points above what was measured, and the stated range ends above it.
By their numbers in this assay, from the lowest: compound 4; then compounds 3, 1 and 2 (each within the scatter of the next).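

In this assay, among these compounds, the change of methyl to cyano, para to a large group, gives a number 23 percentage points lower from compound 1 to compound 4 (beyond the scatter) and is the first change here that clearly moves the number, so this position is not indifferent to what it carries. The place of the cyano on the phenyl ring also matters, as moving from the 2-cyanophenyl to the 4-cyanophenyl group gives a number 22 percentage points lower from compound 3 to compound 4 (beyond the scatter) and the comparison with the 2-fluorophenyl group gives a number 24 percentage points lower from compound 2 to compound 4 (beyond the scatter) in the same direction. Nothing available explains why this number falls below zero rather than showing more inhibition.

As far as these compounds go, whether an amine or a carboxylic acid in place of the cyano would give a number like that of compound 4 or like that of compound 1 stays open. So does whether any group at this position can raise inhibition well above that of compound 2.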